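The source may report more compounds than this note shows. Statements on the series, on what has been measured and on what is new or still open speak of the compounds shown alone.

Measured compounds in a functional assay on cells (Platelet, Homo sapiens) for inhibition; a higher number here means a weaker inhibitor, a lower number a stronger inhibitor:

Compound 1 `CCOC(=O)c1ccc(-c2nn(Cc3ccccc3OC)c3ccccc23)cc1` gives > 10000 nM, a limit of the assay and not a number.
Compound 2 `CCOC(=O)c1ccc(-c2nn(-c3ccoc3)c3ccccc23)cc1` gives > 10000 nM, also a limit.
Compound 3 `CCOC(=O)c1ccc(-c2nn(C(C)C)c3ccccc23)cc1` gives > 10000 nM, again a limit.

Compound 3 therefore stands at the limit of the assay, and the same holds for every value shown (the limit of > 10000 nM in this assay, at which 3 of the 3 values shown sit); no number separates it from compound 1 or compound 2. The measured steps are accordingly unreadable: a step that the two limits leave unreadable from compound 1 to compound 2, a step that the two limits leave unreadable from compound 1 to compound 3 and a step that the two limits leave unreadable from compound 2 to compound 3. Compound 4 `CCOC(=O)c1ccc(-c2nn(-c3ccccc3)c3ccccc23)cc1` is the compound still to be measured. Its change from compound 3 is phenyl in place of isopropyl on an aromatic nitrogen. The measured step most like it in kind, a step that the two limits leave unreadable from compound 2 to compound 3, exchanges furan-3-yl for isopropyl on that same nitrogen and sits between two limits, so it gives no size. No direction and no size in this assay can therefore be read from the measured steps; the three values show only that each substituent tried on this nitrogen leaves the compound at the limit. Compound 4 is estimated at 15000 nM, with an expected range from 3000 nM to 60000 nM, and will most likely again be reported as a limit. This amounts to an expected step that the limit leaves unreadable from compound 3 to compound 4.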

Compound 4, half-maximal inhibitory concentration: > 10000 nM
Compound 4 ended at the assay's limit (the forecaster's own chance of this, stated with the estimate: 75%); the middle value does not contradict the limit.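

No step from compound 1, compound 2 or compound 3 to compound 4 can be read, since each value is a limit and not a number: the limit of > 10000 nM in this assay, at which 4 of the 4 values shown sit.

The compounds shown leave open whether any substituent on this aromatic nitrogen gives a measurable value in this assay.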